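Swapping the Fluorinated Phenyl Group of Compound 3

The compounds below may be only part of what the source reports. "The series", "measured", "known", "first", "only" and "open" are said of these compounds alone.

In a functional assay with Homo sapiens as the target (on this read-out higher numbers stand for weaker inhibition and lower numbers for stronger inhibition), compound 3 `CC(C)[C@H](NC(=O)COc1cccc2ccccc12)C(=O)N[C@@H](CC(=O)O)C(=O)COc1cc(F)cc(F)c1` gives 15900 nM, which lies within the scatter of compound 1 `CC(C)[C@H](NC(=O)COc1cccc2ccccc12)C(=O)N[C@@H](CC(=O)O)C(=O)COc1cccc(C(F)(F)F)c1` at 16600 nM and of compound 2 `CC(C)[C@H](NC(=O)COc1cccc2ccccc12)C(=O)N[C@@H](CC(=O)O)C(=O)COc1ccc(F)cc1` at 14300 nM. Compound 4 `CC(C)[C@H](NC(=O)COc1cccc2ccccc12)C(=O)N[C@@H](CC(=O)O)C(=O)COc1ccc(F)c(F)c1F` differs from compound 3 in one place: 2,3,4-trifluorophenyl in place of 3,5-difluorophenyl on an oxygen on a saturated carbon. There, 2,3,4-trifluorophenyl stands in place of 3,5-difluorophenyl on an oxygen on a saturated carbon. The three measured exchanges of the group at this same place gave a 1.2-fold lower number from compound 1 to compound 2 (0.06 log units; within the scatter), a 1.0-fold lower number from compound 1 to compound 3 (0.02 log units; within the scatter) and a 1.1-fold higher number from compound 2 to compound 3 (0.05 log units; within the scatter), so none of them left the scatter. On that basis, no step beyond the scatter is expected in this assay. Compound 4 is estimated at 15500 nM, with an expected range of 9000 nM to 26000 nM.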

Compound 4, half-maximal inhibitory concentration: 20600 nM
Compound 4: the middle estimate sits 1.3-fold (0.12 log units) below what was measured, within the range that was stated.
By their numbers in this assay, from the lowest: compounds 2, 3, 1 and 4 (each within the scatter of the next).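

The 2,3,4-trifluorophenyl group widens the set of groups seen at this place in this assay without a step beyond the scatter, giving a 1.3-fold higher number from compound 3 to compound 4 (0.11 log units; within the scatter) and a 1.4-fold higher number from compound 2 to compound 4 (0.16 log units; within the scatter) and a 1.2-fold higher number from compound 1 to compound 4 (0.09 log units; within the scatter). Four different fluorinated phenyl groups on this oxygen, one with three fluorine atoms on the ring, therefore give numbers that cannot be told apart on this read-out. No measurement at hand accounts for this flat result. From the compounds shown here alone, all four groups are fluorinated phenyl rings, so it remains open whether a phenyl ring carrying an amine or a carboxylic acid, or a longer chain in place of the ring, would give a step beyond the scatter.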